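A few compounds are considered here, and "the series" means these few. Any claim that something is new, unique, unknown or untested is made for them only; others in the source may bear on it.

Measured compounds in a functional assay on the whole organism for inhibition, with Rattus norvegicus as the target, at a dose of 0.3 mg/kg by the oral route; a higher number here means a stronger effect of the compound at the dose given, a lower number a weaker effect: compound 1 `CNc1ccc(-c2cccc(C(=O)Nc3nn[nH]n3)n2)cc1` gives 29%; compound 2 `CCCc1ccc(-c2cc(C)cc(C(=O)Nc3nn[nH]n3)n2)cc1` gives 19%; compound 3 `CCCCc1ccc(-c2cc(C)cc(C(=O)Nc3nn[nH]n3)n2)cc1` gives 17%.

Compound 3 has the lowest of the three numbers, yet its gap to compound 2 lies within the scatter, and only compound 1 stands beyond it. Compound 4 `CNc1ccc(-c2cc(C)cc(C(=O)Nc3nn[nH]n3)n2)cc1` differs from compound 3 in one place: methylamino in place of butyl on an aromatic carbon. For the measured compounds named here, the only measured step, a number 2 percentage points lower from compound 2 to compound 3 (within the scatter), concerns a change within the butyl chain and is flat, so it says little about swapping that chain for methylamino. Compound 1 carries the same methylamino group, though on a core without the methyl, and gives the highest number. Compound 4 is therefore expected to rise, as a number 9 percentage points higher from compound 3 to compound 4 (within the scatter), to an estimated 26% with a range from 12% to 40%.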

Compound 4, a percentage reported as inhibition, in the whole organism at one dose (the size of the read-out at that dose, not a potency): 36%
Compound 4: the middle estimate sits 10 percentage points below what was measured; measured number inside the range.
By their numbers in this assay, from the lowest: compounds 3, 2, 1 and 4 (each within the scatter of the next, the first and the last beyond it).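

Methylamino in place of butyl brings a number 19 percentage points higher from compound 3 to compound 4 (beyond the scatter) in this assay and methylamino in place of propyl brings a number 17 percentage points higher from compound 2 to compound 4 (beyond the scatter) on the same aromatic carbon, so this position responds to swapping the chain for methylamino, where lengthening the chain alone did not. The methyl on the core shows only a number 7 percentage points higher from compound 1 to compound 4 (within the scatter) in this setting, so it makes no clear difference alongside methylamino. No measurement here explains these differences.

From the compounds shown here alone, whether the rise follows the nitrogen or the shorter chain stays open: an ethyl chain or a dimethylamino group at this position could separate the two. Going by these compounds, a single dose shows only the size of the effect at that dose, so whether these compounds would give a stronger or weaker effect at other doses also stays open.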